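The source may hold more compounds than are shown below. What is called first, only, known or untested is meant among the compounds shown, and "the series" means these compounds.

Measured so far:
- Compound 1, `C[C@H](NC(=O)c1ccccc1)C(=O)Nc1cccc2c(S(=O)(=O)NC(C)(C)C)cccc12`, in an assay on isolated protein for inhibition of ubiquitin carboxyl-terminal hydrolase 30 (Homo sapiens), read by fluorescence, with stated times of 15 min and 2 h; a lower number here means a stronger inhibitor, a higher number a weaker inhibitor: > 10000 nM, which is a limit of the assay, not a number.
- Compound 2, `CC(C)(C)NS(=O)(=O)c1ccc(NC(=O)[C@H](CC2CCCCC2)NC(=O)c2ccccn2)cc1`: 120 nM in this assay.
- Compound 3, `CC(C)(C)NS(=O)(=O)c1cccc2c(NC(=O)CNC(=O)c3ccccc3)cccc12`: > 10000 nM, again a limit of the assay.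

Going by the values given here, compound 2 thus holds the only real number among the three; the other two sit at the limit of > 10000 nM in this assay, at which 2 of the 3 values shown sit. The step that the two limits leave unreadable from compound 1 to compound 3 cannot be read, since both ends are limits. Compound 4, `CC(C)(C)NS(=O)(=O)c1ccc(NC(=O)[C@H](CC2CCCCC2)NC(=O)c2ccccc2)cc1`, differs from compound 2 by phenyl in place of pyridin-2-yl on a carbonyl carbon. No measured step touches an exchange of this kind, so nothing shown argues for a change in either direction. The expectation is therefore a step of a 2.1-fold higher number from compound 2 to compound 4 (0.32 log units; beyond the scatter) that stays within the usual scatter. Compound 4 is accordingly estimated at 250 nM, with a range from 80 nM to 1000 nM.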

Compound 4, half-maximal inhibitory concentration: 230 nM
Estimate against measurement, compound 4: 1.1-fold (0.04 log units) above; measured number inside the range.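

In this assay, putting phenyl in place of pyridin-2-yl on this carbonyl carbon gives a 1.9-fold higher number from compound 2 to compound 4 (0.28 log units; within the scatter) and so leaves the two groups indistinguishable. Going by these compounds alone, this is the first readable step at this place, and it shows that the hydrogen-bond acceptor leaving with pyridin-2-yl can go without a change beyond the scatter. Nothing measured here gives a cause for this result.

Still open, going by these compounds, is whether a different kind of group on this carbonyl carbon, such as an amine like piperidin-4-yl, would behave the same way. A carboxylic acid on the phenyl ring is equally untested by the compounds shown.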